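The source may report more compounds than this note shows. Statements on the series, on what has been measured and on what is new or still open speak of the compounds shown alone.

Compound 1 `CCC(=O)NC/C=C\CN(C)C[C@H]1O[C@@H](n2cnc3c(N)ncnc32)[C@H](O)[C@@H]1O` and compound 2 `CCCC(=O)NC/C=C\CN(C)C[C@H]1O[C@@H](n2cnc3c(N)ncnc32)[C@H](O)[C@@H]1O` share a core that differs from that of compound 3 `CC(=O)NC/C=C\CN(C)C[C@H]1O[C@@H](n2cnc3c(N)ncnc32)[C@H](OC(C)=O)[C@@H]1OC(C)=O` in more than one place; the difference between the two cores is not broken down here. In an ADME assay on microsomes from liver (Mus musculus) for metabolic stability, read by LC-MS, using NADPH, tested at 1 uM (a higher number here means that the compound lasts longer, a lower number that the compound disappears faster), compound 1 gives a value that is a limit of the assay, > 1.5 h. Compound 2 likewise gives a limit in this assay, > 1.5 h. The change methyl in place of hydrogen on a saturated chain carbon, two bonds along the chain from a carbonyl carbon therefore gives a step that the two limits leave unreadable from compound 1 to compound 2, since both values sit at the limit of > 1.5 h in this assay, at which 2 of the 3 values shown sit. In this assay, among the compounds with values here, compound 3 gives 0.11 h, the only number in the set. Compound 4 `CCC(=O)NC/C=C\CN(C)C[C@H]1O[C@@H](n2cnc3c(N)ncnc32)[C@H](OC(C)=O)[C@@H]1OC(C)=O`, not yet measured, differs from compound 3 by methyl in place of hydrogen on a saturated chain carbon bound to a carbonyl carbon, the same kind of change as from compound 1 to compound 2, though placed on a chain carbon bound to the carbonyl carbon rather than two bonds along the chain from it. The step of a 1.1-fold higher number from compound 3 to compound 4 (0.04 log units; within the scatter) is expected to be small, because the pair a step that the two limits leave unreadable from compound 1 to compound 2 shows nothing readable on which a shift could rest. Compound 4 is estimated at 0.12 h in this assay, with a range of 0.05 h to 0.3 h.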

Compound 4, half-life: 0.0767 h
Compound 4: middle estimate off by 1.6-fold (0.19 log units), on the high side; the range from low to high includes it.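

In this assay, methyl in place of hydrogen on a saturated chain carbon bound to a carbonyl carbon gives a 1.4-fold lower number from compound 3 to compound 4 (0.16 log units; within the scatter), so no readable effect appears on the core of compound 3. The step from compound 1 to compound 2 cannot be read, and both of its values are limits of the assay: the limit of > 1.5 h in this assay, at which 2 of the 4 values shown sit. The pairs therefore give no two sizes to set side by side, and the data neither support nor contradict carrying this change from one core to the other.

Open, going by these compounds, is how a hexanoyl chain, or a chain carrying an amine, would read on the core of compound 3. Also open, on these data alone, is whether the same chains would give a number rather than a limit on the core of compound 1.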